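Notes on compound 2 and the unmeasured compound 4

A few compounds are considered here, and "the series" means these few. Any claim that something is new, unique, unknown or untested is made for them only; others in the source may bear on it.

Measured compounds:
Compound 1, `CC(C)(C)[C@@H](O)C(=O)N1Cc2ccccc2[C@H]1C(=O)NCc1cc(Cl)ccc1-n1nnnn1`, in an ADME assay on Caco-2 cells (Homo sapiens) for permeability, read by LC-MS, in the apical to basolateral direction, with a stated time of 60 min, at pH 6.5 (on this read-out lower numbers stand for lower permeability and higher numbers for higher permeability), gives 9 10^-6 cm/s.
Compound 2, `COC(C)(C)[C@@H](O)C(=O)N1N=CC[C@H]1C(=O)NCc1cc(Cl)ccc1-n1cnnn1`, in this assay gives 1.7 10^-6 cm/s.
Compound 3, `CC(C)(C)C[C@@H](O)C(=O)N1OCC[C@H]1C(=O)NCc1cc(Cl)ccc1-n1cnnn1`, in this assay gives 25 10^-6 cm/s.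

Compound 2 holds the lowest of the three numbers in this assay. Its nearest neighbour is compound 1, whose number stands higher by a margin beyond the usual scatter; compound 3 stands higher still, also beyond the scatter. Among the compounds with values here, the three compounds differ from each other in more than one place, so no single step between measured compounds can be read from these values; they show only that compound 2 sits at the bottom of the range seen so far.

The unmeasured compound 4, `CC(C)(C)[C@@H](O)C(=O)N1N=CC[C@H]1C(=O)NCc1cc(Cl)ccc1-n1cnnn1`, is reached from compound 2 by one change:
methyl in place of methoxy on a saturated chain carbon bound to three saturated chain carbons

Within the data shown here, no measured pair shows this change on its own. The expectation for this assay is a step upward from compound 2, of moderate size, with a fair chance that it stays within the scatter of repeated measurements. Compound 4 is expected to give 4 10^-6 cm/s, with a range from 1.5 10^-6 cm/s to 11 10^-6 cm/s. This estimate means an expected step of a 2.4-fold higher number from compound 2 to compound 4 (0.37 log units; beyond the scatter), which is still expected to leave compound 4 well short of the number seen for compound 3.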

Compound 4, apparent permeability: 15 10^-6 cm/s
Estimate against measurement, compound 4: 3.8-fold (0.57 log units) below, outside the stated range (above it).
By their numbers in this assay, from the lowest: compound 2; then compounds 1, 4 and 3 (each within the scatter of the next, the first and the last beyond it).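

In this assay, within the data shown here, this is the first change that can be read on its own: methyl in place of methoxy on a saturated chain carbon bound to three saturated chain carbons gives an 8.8-fold higher number from compound 2 to compound 4 (0.95 log units; beyond the scatter), with the rest of the structure held constant. The position is therefore not silent on this read-out. The change takes out one heavy atom and one hydrogen-bond acceptor, but nothing at hand bears on why the step has this size.

This single pair leaves open whether 1-methoxy-1-methylethyl to tert-butyl gives a step of similar size on the core of compound 1 or the core of compound 3. It also leaves open how the read-out would respond on the core of compound 2 if a hydroxyl, an amine or a carboxylic acid stood in place of the methoxy on that same carbon.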